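A few compounds are considered here, and "the series" means these few. Any claim that something is new, unique, unknown or untested is made for them only; others in the source may bear on it.

Compound 2 `CN(C)CCn1c(=O)c(=Cc2ccc(F)c(F)c2)s/c1=C1\C(=O)Nc2ccc(F)cc21` gives 9480 nM in a functional assay on MDA-MB-231 cells (Homo sapiens) for inhibition, read by MTT assay, with a stated time of 72 h (on this read-out higher numbers stand for weaker inhibition and lower numbers for stronger inhibition), the highest of the three numbers measured, though compound 1 `Cc1ccc2c(c1)/C(=c1/sc(=Cc3ccc(C=O)c(C=O)c3)c(=O)n1CCN(C)C)C(=O)N2` gives 8100 nM, which lies within the scatter of it, while compound 3 `CN(C)CCn1c(=O)c(=Cc2ccc(O)cc2)s/c1=C1\C(=O)Nc2ccc(F)cc21` gives 4200 nM. Among the measured compounds shown here, the one measured step, a 2.3-fold lower number from compound 2 to compound 3 (0.35 log units; beyond the scatter), changed the aryl group on the double-bonded chain carbon, not the fused ring. Compound 4 `Cc1ccc2c(c1)/C(=c1/sc(=Cc3ccc(F)c(F)c3)c(=O)n1CCN(C)C)C(=O)N2` differs from compound 2 by methyl in place of fluoro on an aromatic carbon. Compounds 1 and 2 differ at that same carbon but also in the aryl group, so their two values show only numbers within the scatter of each other. For the measured compounds named here, no measured step bears directly on this change, so no step beyond the scatter is expected in this assay. Compound 4 is therefore estimated at 8500 nM, between 4500 nM and 16000 nM. The expected step is a 1.1-fold lower number from compound 2 to compound 4 (0.05 log units; within the scatter).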

Compound 4, half-maximal inhibitory concentration: > 200000 nM
Compound 4: no number, only a limit; the forecaster's own chance of this, stated with the estimate: 5%; middle value at least 23-fold (1.37 log units) from the limit.
By their numbers in this assay, from the lowest: compounds 3, 1 and 2 (each within the scatter of the next, the first and the last beyond it). At a limit, above all of these: compound 4.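

Methyl in place of fluoro at this aromatic carbon turns out to matter greatly in this assay, giving an at least 21-fold higher number from compound 2 to compound 4 (1.32 log units; beyond the scatter). Methyl alone does not decide the outcome, since changing only the aryl group, with methyl kept, gives an at least 24-fold higher number from compound 1 to compound 4 (1.39 log units; beyond the scatter). The value of compound 4 is a limit of the assay and not a number, so both steps give only a smallest size: the limit of > 200000 nM in this assay, at which 1 of the 4 values shown sits.

Still open, going by these compounds, is whether an amine or a methoxy group at this carbon would behave like fluoro or like methyl. Also open, on these data alone, is how the 4-hydroxyphenyl group of compound 3 would behave alongside methyl.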